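This account rests on a few compounds, and the source may have more. Where it says the series, first, only, none or still open, it means among the compounds named here.

In a functional assay on A549 cells (Homo sapiens) for cytotoxicity, read by MTT assay, with a stated time of 72 h (on this read-out lower numbers stand for stronger inhibition and higher numbers for weaker inhibition), three compounds have been measured so far. Compound 1 (`COc1ccc(CCCOC(=O)CCc2ccc(O)cc2)cc1`) gives 186000 nM in this test. Compound 3 (`O=C(CCc1ccc(O)c(O)c1)OCCCc1ccccc1`) gives 138000 nM under the same conditions. Compound 2 (`COc1cc(/C=C/COC(=O)/C=C/c2cc(OC)c(OC)c(OC)c2)cc(OC)c1OC`) gives 180000 nM and cannot be separated from the other two: its gaps to both lie within the usual scatter of repeated measurements. The next compound to be tested is compound 4 (`COc1ccc(/C=C/COC(=O)/C=C/c2cc(OC)c(OC)c(OC)c2)cc1OC`). It differs from compound 2 by hydrogen in place of methoxy on an aromatic carbon and is otherwise the same. For the measured compounds named here, no measured pair shows this change on its own, so the expectation has little to rest on. The three measured structures are unlike one another, yet their numbers stay together, with compound 1 at 186000 nM and compound 3 at 138000 nM in the same range. The expected step in this assay is a 1.2-fold lower number from compound 2 to compound 4 (0.08 log units; within the scatter) and it is not expected to go beyond the scatter in either direction. For compound 4 the estimated value is 150000 nM with an expected range from 70000 nM to 300000 nM in the measurement still to come.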

Compound 4, half-maximal inhibitory concentration: 172000 nM
Estimate against measurement, compound 4: 1.1-fold (0.06 log units) below; the range from low to high includes it.
By their numbers in this assay, from the lowest: compounds 3, 4, 2 and 1 (each within the scatter of the next).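

In this assay, for the compounds shown here, the pair formed by compound 2 and compound 4 is the first to differ in one place, and the exchange gives a 1.0-fold lower number from compound 2 to compound 4 (0.02 log units; within the scatter). This shows that, in the setting of compound 2, replacing the methoxy group on an aromatic carbon with hydrogen, at a place ortho to a methoxy group and meta to a large group, leaves the number within the scatter, something the three structurally unlike earlier compounds could only hint at through their similar values. Nothing at hand offers an explanation for this result.

Going by these compounds, only hydrogen and methoxy have been compared at this position, so it remains open whether an amine, a carboxylic acid or a longer alkoxy chain there would also stay within the scatter. On these data alone, it is also open whether the same exchange would give so small a step at the other methoxy groups, on the other aromatic ring, or in a compound with a different link between the two rings.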